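Swapping an aryl for an arylpropyl chain on the ring nitrogen

A few compounds are considered here, and "the series" means these few. Any claim that something is new, unique, unknown or untested is made for them only; others in the source may bear on it.

Three compounds share one core and differ only in the group on an amine nitrogen in a ring. Compound 1 `Nc1scc(CN2CCN(c3ccc(F)cc3Cl)CC2)c1C(=O)c1ccc(Cl)cc1` gives -70% in a functional assay on CHO cells with adenosine receptor A1 (Homo sapiens) as the target, read by cAMP accumulation and immunoassay, with a stated time of 6 min, tested at 10 uM; a higher number here means a weaker effect of the compound at the concentration tested, a lower number a stronger effect. Compound 2 `Nc1scc(CN2CCN(c3ccccc3C(F)(F)F)CC2)c1C(=O)c1ccc(Cl)cc1` gives -60%, and compound 3 `Nc1scc(CN2CCN(c3ccccc3F)CC2)c1C(=O)c1ccc(Cl)cc1` gives -15%. Compound 2 stands second highest of the three; its nearest neighbour is compound 1, with a number 10 percentage points higher from compound 1 to compound 2 (within the scatter), while the gap to compound 3 is a number 45 percentage points higher from compound 2 to compound 3 (beyond the scatter), and a number 55 percentage points higher from compound 1 to compound 3 (beyond the scatter) is of the same kind.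

Compound 4 `Nc1scc(CN2CCN(CCCc3ccc(Cl)cc3)CC2)c1C(=O)c1ccc(Cl)cc1` is not yet measured. The change from compound 2 is 3-(4-chlorophenyl)propyl in place of 2-(trifluoromethyl)phenyl on an amine nitrogen in a ring. Among the compounds with values here, every measured step exchanges one aryl group for another; none replaces an aryl with a chain such as 3-(4-chlorophenyl)propyl, so no measured step bears directly. The measured steps do show that this position can shift the number by large amounts. The expectation for a number 25 percentage points higher from compound 2 to compound 4 (beyond the scatter) is therefore uncertain, leaning toward a weaker effect. Compound 4 is estimated at -35%, within -80% to 10%.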

Compound 4, a percentage reported as activity, at one concentration (the size of the read-out at that concentration, not a potency): -76%
Compound 4: the middle estimate sits 41 percentage points above what was measured; measured number inside the range.
By their numbers in this assay, from the lowest: compounds 4, 1 and 2 (each within the scatter of the next, the first and the last beyond it); then compound 3.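

The aryl ring need not sit directly on the ring nitrogen: in this assay, 3-(4-chlorophenyl)propyl, with the same count of heavy atoms as 2-(trifluoromethyl)phenyl, gives a number 16 percentage points lower from compound 2 to compound 4 (beyond the scatter) and so a somewhat stronger effect. The chain also stands level with the best aryl group, with a number 6 percentage points lower from compound 1 to compound 4 (within the scatter), and far from the 2-fluorophenyl group, with a number 61 percentage points lower from compound 3 to compound 4 (beyond the scatter), so a flexible chain at this position can do as well as a directly attached aryl group. Nothing available explains why this chain performs as it does.

As far as these compounds go, it remains open whether a shorter or a longer chain would hold the effect. A plain 3-phenylpropyl group would show how much depends on the chlorine of the chain's ring.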